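Adding a second chloro to a thiourea-type growth inhibitor

This account rests on a few compounds, and the source may have more. Where it says the series, first, only, none or still open, it means among the compounds named here.

Of the compounds shown here, two have been measured in a functional assay on MDA-N cells (Homo sapiens) for inhibition, read by sulforhodamine B assay, with a stated time of 48 h; a lower number here means a stronger inhibitor of growth, a higher number a weaker inhibitor of growth. Compound 1 `COc1cc(C(=O)N2CCN(C=O)C2=S)cc(OC)c1OC` gives 17900 nM. Compound 2 `O=CN1CCN(c2ccc(Cl)cc2)C1=S` gives 16600 nM. The two numbers lie within the usual scatter of each other, so neither compound can be called the stronger inhibitor; both are weak on this scale. Compound 3 `O=CN1CCN(c2ccc(Cl)c(Cl)c2)C1=S` has not yet been measured in this assay. It differs from compound 2 in one place: chloro in place of hydrogen on an aromatic carbon. Among the measured compounds shown here, no measured pair shows what such a change does here, so the expectation rests on general experience rather than on a step seen in these data. The change is small, and a step no larger than a modest one, in either direction, is expected; a slight move toward a lower number seems somewhat more likely than not. For compound 3 the expected step is a 1.7-fold lower number from compound 2 to compound 3 (0.22 log units; within the scatter). Compound 3 is estimated at 10000 nM, with a range from 3000 nM to 40000 nM.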

Compound 3, concentration for 50% growth inhibition: 15600 nM
Compound 3: middle estimate off by 1.6-fold (0.19 log units), on the low side; measured number inside the range.
By their numbers in this assay, from the lowest: compounds 3, 2 and 1 (each within the scatter of the next).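

In this assay, among the compounds shown here, the single swap of chloro in place of hydrogen on an aromatic carbon can now be read directly for the first time (a 1.1-fold lower number from compound 2 to compound 3 (0.03 log units; within the scatter)). At this place, ortho to a chloro group and meta to a group of 8 heavy atoms, the added chloro gives a number that cannot be told apart from that of compound 2, so this one change does not turn the weak inhibitor into a clearly stronger or weaker one. No measurement bears on what lies behind this result. Still open, as far as these compounds go, is whether an amine, a carboxylic acid or a longer chain at this same place would give a number beyond the scatter. Also open, from the compounds shown here alone, is whether a chloro elsewhere on the ring would do so.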